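This account rests on a few compounds, and the source may have more. Where it says the series, first, only, none or still open, it means among the compounds named here.

Series notes. In a functional assay on ZR-75-1 cells (Homo sapiens) for cytotoxicity, read by MTT assay, with a stated time of 72 h (on this read-out lower numbers stand for an effect already at smaller amounts and higher numbers for an effect only at larger amounts of compound), compound 1 `CCc1cccc2c(O)c(-c3occ(C)c3C(=O)O)ccc12` gives 0.3 ug/mL. Compound 3 `CCOc1c(-c2occ(C)c2C(=O)OC)ccc2c(CC)cccc12` gives 1.2 ug/mL in this assay. Compound 2 `CCc1cccc2c(OC)c(-c3occ(C)c3C(=S)OC)ccc12` gives 5.8 ug/mL in this assay, the highest of the three numbers; compound 3 stands a step below it that is beyond the scatter, and compound 1 stands further below still, also beyond the scatter. Compound 4 `CCOCc1c(C)coc1-c1ccc2c(CC)cccc2c1OC` has not been measured. It differs from compound 2 in one place: a group of 4 heavy atoms (3 carbon, 1 oxygen; no ring) in place of a group of 4 heavy atoms (2 carbon, 1 oxygen, 1 sulfur; no ring), on an aromatic carbon. Among the compounds with values here, no measured pair of the series carries this change, so the size of the step in this assay is uncertain. A modest step toward lower numbers is expected for compound 4, a 1.7-fold lower number from compound 2 to compound 4 (0.22 log units; within the scatter), not clearly beyond the scatter. Compound 4 is accordingly estimated at 3.5 ug/mL, with a range from 1 ug/mL to 12 ug/mL.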

Compound 4, concentration for half-maximal effect: 9.1 ug/mL
Estimate against measurement, compound 4: 2.6-fold (0.41 log units) below, and the stated range covers the measured number.
By their numbers in this assay, from the lowest: compound 1; then compound 3; then compounds 2 and 4 (each within the scatter of the next).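

On the aromatic carbon of the five-membered ring, ethoxymethyl in place of the sulfur-containing group gives a 1.6-fold higher number from compound 2 to compound 4 (0.20 log units; within the scatter) in this assay. This position can therefore carry a group without sulfur and without a double bond outside aromatic rings, with no step beyond the scatter. No measurement here explains this result.

Still open, as far as these compounds go, is whether an amine, an amide or a chain longer than ethoxymethyl on this carbon would also stay within the scatter of compound 2.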